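Replacing benzyloxy with amino in compound 2

The source may hold more compounds than are shown below. What is called first, only, known or untested is meant among the compounds shown, and "the series" means these compounds.

Compound 1 `COc1cccc(/C=C/C(=O)Nc2cc(OC)c(OC)c(OC)c2)c1`: 23400 nM
Compound 2 `COc1cc(NC(=O)/C=C/c2cccc(OCc3ccccc3)c2)cc(OC)c1OC`: 17300 nM
Compound 3 `C=C(Br)C(=O)Nc1cccc(/C=C/C(=O)Nc2ccc(OC(F)(F)F)cc2)c1`: 13000 nM
Compound 4 `COc1cc(NC(=O)/C=C/c2cccc(N)c2)cc(OC)c1OC`: not yet measured

In a functional assay on CCRF-CEM cells (Homo sapiens) for inhibition, read by MTT assay, with a stated time of 72 h (on this read-out lower numbers stand for stronger inhibition and higher numbers for weaker inhibition), compound 2 gives 17300 nM, which lies within the scatter of both compound 1 and compound 3. The next change is amino in place of benzyloxy on an aromatic carbon, or amino in place of benzyloxy on an aromatic carbon. Within the data shown here, one measured step bears on it: a 1.4-fold lower number from compound 1 to compound 2 (0.13 log units; within the scatter). That step builds the benzyloxy group that now leaves, and it stayed within the scatter. Among the measured compounds shown here, no measured compound shows what amino does in this place, so the expectation is weakly founded. In this assay the expected step is a 1.4-fold higher number from compound 2 to compound 4 (0.16 log units; within the scatter), with no clear shift beyond the scatter foreseen. Compound 4 is estimated at 25000 nM, within an expected range from 8000 nM to 70000 nM.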

Compound 4, half-maximal inhibitory concentration: 40900 nM
Compound 4: middle estimate off by 1.6-fold (0.21 log units), on the low side, and the stated range covers the measured number.
By their numbers in this assay, from the lowest: compounds 3, 2, 1 and 4 (each within the scatter of the next, the first and the last beyond it).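

In this assay, this position does respond to what sits on it: amino in place of benzyloxy gives a 2.4-fold higher number from compound 2 to compound 4 (0.37 log units; beyond the scatter) and lies beyond the scatter, while the earlier step that built benzyloxy stayed within it. Amino in place of methoxy gives a 1.7-fold higher number from compound 1 to compound 4 (0.24 log units; within the scatter) and stays within the scatter, so amino and methoxy cannot be told apart here. Nothing among the data gives a reason for either step.

From the compounds shown here alone, whether a hydroxyl group, a dimethylamino group or a longer ether chain such as ethoxy would shift the number at this place remains open.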